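One Number to Build On: From Compound 3 to Compound 4

The source may report more compounds than this note shows. Statements on the series, on what has been measured and on what is new or still open speak of the compounds shown alone.

Going by the values given here, only one of three related compounds has yet given a true number. In a functional assay on NALM-6 cells (Homo sapiens) for cytotoxicity, with a stated time of 72 h (a lower number here means that less compound is needed, a higher number that more compound is needed for the effect), compound 1 `C=C[C@@](C)(/C=C/c1ccc(OS(=O)(=O)c2ccc(C)cc2)cc1)CCC=C(C)C` gives > 43400 nM as a limit of the assay, not a number. Compound 2 `C=C[C@@](C)(/C=C/c1ccc(O)cc1)CC/C=C(\C)C(=O)OCC` gives > 43400 nM as a limit too. Among the compounds with values here, compound 3 `C=C[C@@](C)(/C=C/c1ccc(O)c(CO)c1)CCC=C(C)C` gives 16400 nM as the only real number of the three.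

Compound 4 `C=C[C@@](C)(/C=C/c1ccc(O)c(/C=C/C(N)=O)c1)CCC=C(C)C` is still unmeasured. It carries 2-carbamoylethenyl in place of hydroxymethyl on an aromatic carbon, ortho to a hydroxy group, and the counted difference is 2-carbamoylethenyl in place of hydroxymethyl on an aromatic carbon with the rest of the structure unchanged.

Within the data shown here, no two measured compounds differ in one place only, so the size of such a swap has not been seen directly. The estimate therefore starts from compound 3 at 16400 nM as its sole anchor. The expected change a 1.1-fold lower number from compound 3 to compound 4 (0.04 log units; within the scatter) is no larger than the usual scatter and has no firm direction. For compound 4 the estimated value is 15000 nM with an expected range from 5000 nM to 40000 nM as the likely span.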

Compound 4, half-maximal effective concentration: > 43400 nM
Compound 4 gave a limit, no number (the forecaster's own chance of this, stated with the estimate: 25%); middle value at least 2.8-fold (0.46 log units) away from the limit.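

Going by these compounds alone, this is the first direct reading of a single change at this position on the ring. In this assay, putting 2-carbamoylethenyl in place of hydroxymethyl on the aromatic carbon ortho to a hydroxy group gives an at least 2.6-fold higher number from compound 3 to compound 4 (0.42 log units; beyond the scatter), so more compound is needed and the position is not indifferent to what it carries. Going by these compounds, that step is only a minimum, and its full size stays unknown because of a ceiling on the read-out: the limit of > 43400 nM in this assay, at which 3 of the 4 values shown sit.

The compounds shown cannot separate the part played by the double bond from that of the carbamoyl end or the longer chain. They also leave open how a shorter group at the same carbon, such as an aminomethyl or a carboxylic acid, would compare with hydroxymethyl.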